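The compounds below may be only part of what the source reports. "The series", "measured", "known", "first", "only" and "open" are said of these compounds alone.

Compound 1 `Cc1cc(Cl)ccc1NC(=O)Nc1nc(NC2CC2)cc(Sc2c[nH]c3ccccc23)n1` carries a shared core, and in a functional assay on MDA-MB-231 cells (Homo sapiens) for inhibition, with a stated time of 72 h (a higher number here means a weaker inhibitor, a lower number a stronger inhibitor), compound 1 gives 14600 nM. Among the two numbers shown, compound 1 stands at the higher one, though the distance to compound 2 `COc1ccc(NC(=O)Nc2nc(Sc3c[nH]c4ccccc34)cc(N3CCCCC3)n2)cc1`, which gives 7260 nM, lies within the scatter. Compound 3 `COc1cc(NC(=O)Nc2nc(Nc3cc(OC)cc(OC)c3)cc(Sc3c[nH]c4ccccc34)n2)cc(OC)c1` reaches only a limit in this assay, > 50000 nM, which is the limit of > 50000 nM in this assay, at which 1 of the 3 values shown sits. Compound 4 `O=C(Nc1ccccc1)Nc1nc(NC2CC2)cc(Sc2c[nH]c3ccccc23)n1` is not yet measured in this assay; it differs from compound 1 by phenyl in place of 4-chloro-2-methylphenyl on an amide-type nitrogen. Within the data shown here, no measured pair isolates this change, so the record gives no direction for it. Compound 4 is therefore expected to sit close to compound 1, with a step of a 1.4-fold higher number from compound 1 to compound 4 (0.14 log units; within the scatter) no larger than the scatter. Compound 4 is estimated at 20000 nM, within a range from 6000 nM to 50000 nM.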

Compound 4, half-maximal inhibitory concentration: 7860 nM
Compound 4: the middle estimate sits 2.5-fold (0.41 log units) above what was measured; the measured number falls inside the stated range.
By their numbers in this assay, from the lowest: compounds 2, 4 and 1 (each within the scatter of the next). At a limit, above all of these: compound 3.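

This is the only pair shown that differs in one place, and in this assay phenyl in place of 4-chloro-2-methylphenyl on an amide-type nitrogen gives a 1.9-fold lower number from compound 1 to compound 4 (0.27 log units; within the scatter). At this position, then, a ring with neither the chlorine nor the methyl cannot be told apart from the substituted ring. Nothing measured here offers a cause for this step. Going by these compounds, it remains open whether a carboxylic acid, an amine or a pyridine ring on that nitrogen would move the number beyond the scatter.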